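The source may report more compounds than this note shows. Statements on the series, on what has been measured and on what is new or still open speak of the compounds shown alone.

For the measured compounds named here, in an ADME assay on TZM cells (Homo sapiens) for cytotoxicity, read by XTT assay, with a stated time of 4 days (a higher number here means that more compound is tolerated, a lower number that less compound is tolerated), compound 1 `CC(=O)CCc1cc(C)c(Oc2cc(Nc3ccc(C#N)cc3)c(N)cc2C(F)(F)F)c(C)c1` gives 11100 nM, the only true number among the measured compounds. Compound 2 `CC(=O)/C=C/c1cc(C)c(Oc2cc(Nc3ccc(C#N)cc3)c(N)cc2C(F)(F)F)c(C)c1` stands at > 8600 nM, which is a limit of the assay and not a number. Compound 3 `COC(=O)c1cc(N)c(Nc2ccc(C#N)cc2)cc1Oc1c(C)cc(/C=C/C#N)cc1C` also reaches only a limit, > 22800 nM. So the position of compound 2 is only partly known: no measured value places it exactly.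

Compound 4 `Cc1cc(C#N)cc(C)c1Oc1cc(Nc2ccc(C#N)cc2)c(N)cc1C(F)(F)F` differs from compound 2 by one change: cyano in place of 2-acetylethenyl on an aromatic carbon. Here cyano takes the place of 2-acetylethenyl on an aromatic carbon, meta to two methyl groups and para to a large group.

Going by the values given here, one measured step bears on this, since it also changes the group on that aromatic carbon: a step that the limit leaves unreadable from compound 1 to compound 2. Its size cannot be read, so it offers no measured effect to carry over to the new change. The best anchor is compound 1 at 11100 nM, and the estimate stays close to that number. In this assay, the expected step that the limit leaves unreadable from compound 2 to compound 4 is no larger than the usual scatter, with no direction expected. For compound 4 the estimated value is 12000 nM, with an expected range from 5000 nM to 30000 nM.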

Compound 4, half-maximal cytotoxic concentration: 13300 nM
Compound 4: middle estimate off by 1.1-fold (0.04 log units), on the low side, and the stated range covers the measured number.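

For the compounds shown here, until now this aromatic carbon had no step whose size could be read, and compound 4 supplies the first: in this assay, cyano in place of 2-acetylethyl gives a 1.2-fold higher number from compound 1 to compound 4 (0.08 log units; within the scatter). Two true numbers now stand for this position, and cyano and 2-acetylethyl cannot be told apart in this assay, so for these two groups the choice leaves the tolerated concentration within ordinary repeat variation. The steps from compound 1 to compound 2 and from compound 2 to compound 4 both stay unreadable, because compound 2 reaches only a limit, which is not a number: the limit of > 8600 nM in this assay, at which 1 of the 4 values shown sits.

On these data alone, how 2-acetylethenyl compares with cyano or with 2-acetylethyl on this carbon therefore remains open, since it would take a true number for compound 2 to settle it. Also open, as far as these compounds go, is whether the same flat reading in this assay would hold for quite different groups at this position, such as an amine, a carboxylic acid or a longer carbon chain, because two groups that read alike say little about the rest.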